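The source may report more compounds than this note shows. Statements on the series, on what has been measured and on what is new or still open speak of the compounds shown alone.

Measured so far in a functional assay on PC-12 cells (Rattus norvegicus) for cytotoxicity, read by MTT assay, with stated times of 2 h and 24 h, tested at 10 uM; a lower number here means a weaker effect, a higher number a stronger effect of the compound at the concentration tested:

compound 1 `Oc1cc(C(F)(F)F)ccc1-c1nc(-c2ccccc2O)n(-c2ccc(F)cc2)n1` gives 99.8%
compound 2 `COc1ccc(-n2nc(-c3ccc(C(F)(F)F)cc3O)nc2-c2ccccc2O)cc1` gives 98.9%
compound 3 `Oc1cc(C(F)(F)F)ccc1-c1nc(-c2ccccc2O)n(-c2ccc(OC(F)(F)F)cc2)n1` gives 92.5%

Compound 3 stands lowest of the three numbers, but the steps of a number 6.4 percentage points lower from compound 2 to compound 3 (within the scatter) and a number 7.3 percentage points lower from compound 1 to compound 3 (within the scatter) are both within the scatter, so the three measured compounds are not separated in this assay. All three share the same core and differ only in the group on the aromatic carbon of the aryl ring that sits on the aromatic nitrogen of the five-membered ring.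

Compound 4 `COc1ccccc1-n1nc(-c2ccc(C(F)(F)F)cc2O)nc1-c1ccccc1O` is not yet measured. Its difference from compound 3: 2-methoxyphenyl in place of 4-(trifluoromethoxy)phenyl on an aromatic nitrogen. This again exchanges the aryl group on the aromatic nitrogen, the same place touched by every measured step. Those steps, a number 0.9 percentage points lower from compound 1 to compound 2 (within the scatter), a number 7.3 percentage points lower from compound 1 to compound 3 (within the scatter) and a number 6.4 percentage points lower from compound 2 to compound 3 (within the scatter), were all within the scatter, so variation at this position has so far not moved the read-out in this assay. The step of a number 3.5 percentage points higher from compound 3 to compound 4 (within the scatter) is therefore expected to stay within the scatter, with no direction to call. Compound 4 is estimated at 96%, in the range 86% to 100%.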

Compound 4, a percentage reported as activity, at one concentration (the size of the read-out at that concentration, not a potency): 96.2%
Estimate against measurement, compound 4: 0.2 percentage points below; measured number inside the range.
By their numbers in this assay, from the lowest: compounds 3, 4, 2 and 1 (each within the scatter of the next).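

In this assay, among these compounds, the earlier compounds carried only 4-fluorophenyl, 4-methoxyphenyl or 4-(trifluoromethoxy)phenyl on the aromatic nitrogen, so compound 4 is the first test of a different place for the substituent on this aryl ring. The direct comparison of 2-methoxyphenyl with 4-methoxyphenyl gives a number 2.7 percentage points lower from compound 2 to compound 4 (within the scatter) and so does not separate the two methoxy isomers, while the exchanges that give a number 3.7 percentage points higher from compound 3 to compound 4 (within the scatter) and a number 3.6 percentage points lower from compound 1 to compound 4 (within the scatter) likewise stay within the scatter. Across these four compounds, the read-out at this position is therefore unmoved by the nature of the aryl substituent or by its place on the ring, and no measurement on hand bears on the reason for this.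

What the compounds leave open is whether a group of another kind on the aromatic nitrogen, such as an aminophenyl, a carboxylic acid on the aryl ring or a longer alkyl chain in place of the aryl ring, would move the read-out. Among the compounds shown here, all four compounds also keep the 2-hydroxyphenyl and 2-hydroxy-4-(trifluoromethyl)phenyl groups, so the part these play remains untested, and a single tested concentration gives no potency for any compound.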